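Anilino for methylsulfonyl on the amide side chain

The source may hold more compounds than are shown below. What is called first, only, known or untested is meant among the compounds shown, and "the series" means these compounds.

In a functional assay on A549 cells (Homo sapiens) for antiproliferative activity, read by MTT assay, with a stated time of 48 h (a lower number here means a stronger inhibitor, a higher number a weaker inhibitor), compound 1 (`Cc1c(C(=O)NCCCN(C)C)oc2ccc(N(Cc3ccc(Br)cc3)S(=O)(=O)c3ccc(Br)cc3)cc12`) gives 4310 nM. Compound 2 (`Cc1c(C(=O)NCCS(C)(=O)=O)oc2ccc(N(Cc3ccc(Br)cc3)S(=O)(=O)c3ccc(Br)cc3)cc12`) reads > 40000 nM, which is a limit of the assay and not a number. Compound 3 (`Cc1c(C(=O)NCCNc2ccccc2)oc2ccc(N(Cc3ccc(Br)cc3)S(=O)(=O)c3ccc(Br)cc3)cc12`) carries anilino in place of methylsulfonyl on a saturated chain carbon, two bonds along the chain from an amide-type nitrogen. Within the data shown here, the one measured step bearing on this place is an at least 9.2-fold higher number from compound 1 to compound 2 (0.96 log units; beyond the scatter), beyond the scatter, where methylsulfonyl entered in place of (dimethylamino)methyl. Among the measured compounds shown here, with methylsulfonyl leaving again, a move to a lower number in this assay is expected, but anilino has no measured precedent here, and only part of that distance is expected to be recovered. The expected step is an at least 2.8-fold lower number from compound 2 to compound 3 (0.45 log units; beyond the scatter). For compound 3 the estimated value is 14000 nM, with an expected range of 4500 nM to 40000 nM.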

Compound 3, half-maximal inhibitory concentration: > 40000 nM
Compound 3: only a limit was reported; the forecaster's own chance of this, stated with the estimate: 30%; middle value at least 2.8-fold (0.45 log units) from the limit.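

In this assay compound 3 reads > 40000 nM, a limit of the assay and not a number. Anilino in place of (dimethylamino)methyl gives an at least 9.2-fold higher number from compound 1 to compound 3 (0.96 log units; beyond the scatter), so the loss seen with methylsulfonyl recurs with a group that brings an aromatic ring and a hydrogen-bond donor. Of the three compounds only compound 1 reads short of the limit, and the step from methylsulfonyl to anilino cannot be read, because both values are limits: the limit of > 40000 nM in this assay, at which 2 of the 3 values shown sit.

On these data alone, whether the dimethylamino group itself or the chain that carries it sets the value of compound 1 stays open. A primary amine, a morpholine ring or a carboxylic acid at the chain end, or a longer chain bearing dimethylamino, would bear on that question.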